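This account rests on a few compounds, and the source may have more. Where it says the series, first, only, none or still open, it means among the compounds named here.

Measured compounds:
compound 1 `C[C@@H](O[C@H]1CN2C(=O)C=C(c3ccc(C#N)cc3)CC2[C@@H]1c1ccc(F)cc1)c1cc(C(F)(F)F)cc(C(F)(F)F)c1` — 53 nM
compound 2 `C[C@@H](O[C@H]1CN2C(=O)C=C(c3ccc(F)cc3)CC2[C@@H]1c1ccc(F)cc1)c1cc(C(F)(F)F)cc(C(F)(F)F)c1` — 100 nM
compound 3 `C[C@@H](O[C@H]1CN2C(=O)C=C(c3cc[n+]([O-])cc3)CC2[C@@H]1c1ccc(F)cc1)c1cc(C(F)(F)F)cc(C(F)(F)F)c1` — 2.1 nM

In an assay on CHO cells for displacement of a labelled ligand from Substance-P receptor (Homo sapiens), in the presence of a further agent that is not named here (a lower number here means a stronger inhibitor, a higher number a weaker inhibitor), compound 1 stands second highest of the three numbers; compound 2 sits within the scatter of it, while compound 3 lies far below. Compound 4 `C[C@@H](O[C@H]1CN2C(=O)C=C(C3=CCOCC3)CC2[C@@H]1c1ccc(F)cc1)c1cc(C(F)(F)F)cc(C(F)(F)F)c1` has not yet been measured. The change is a group of 6 heavy atoms (5 carbon, 1 oxygen; one six-membered non-aromatic ring with 1 hetero atom) in place of a group of 8 heavy atoms (7 carbon, 1 nitrogen; one six-membered aromatic ring of carbon only), on a double-bonded ring carbon. Among the compounds with values here, two steps touch the same place: a 1.9-fold higher number from compound 1 to compound 2 (0.28 log units; within the scatter) and a 25-fold lower number from compound 1 to compound 3 (1.40 log units; beyond the scatter). The first shows that swapping one aromatic substituent for another there can leave the number unchanged; the second shows that a ring bearing a hetero atom can lower it greatly. The entering group is neither of these, so a moderate move is expected, leaning lower, as a 1.5-fold lower number from compound 1 to compound 4 (0.18 log units; within the scatter). Compound 4 is therefore estimated at 35 nM, expected between 8 nM and 150 nM.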

Compound 4, half-maximal inhibitory concentration: 9.6 nM
Compound 4: the middle estimate sits 3.6-fold (0.56 log units) above what was measured; the measured number falls inside the stated range.
By their numbers in this assay, from the lowest: compound 3; then compound 4; then compounds 1 and 2 (each within the scatter of the next).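

A ring at this double-bonded ring carbon need not be aromatic to give a low number: the oxygen-bearing ring of compound 4 gives a 5.5-fold lower number from compound 1 to compound 4 (0.74 log units; beyond the scatter) and a 10-fold lower number from compound 2 to compound 4 (1.02 log units; beyond the scatter). It still does not match the aromatic ring with a hetero atom, with a 4.6-fold higher number from compound 3 to compound 4 (0.66 log units; beyond the scatter). Nothing measured here explains these differences. Open, going by these compounds, is whether the oxygen or the ring double bond of compound 4 matters more, and how a piperidine ring or an open methoxyethyl chain would compare at this carbon.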